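The compounds below may be only part of what the source reports. "The series", "measured", "known", "first", "only" and "open" are said of these compounds alone.

Compound 1 `Fc1cc(Cl)ccc1-c1ccc(Cn2nnc3ccccc32)cn1` gives 50 nM in a functional assay on cells for positive allosteric modulation of metabotropic glutamate receptor 2 (Homo sapiens), read by fluorescence and calcium flux, with a stated time of 30 min; a lower number here means that less compound is needed, a higher number that more compound is needed for the effect.
Compound 2 `Clc1ccc(-c2ccc(Cn3nnc4ccccc43)cn2)cc1` gives 70 nM in this assay.
Compound 3 `Brc1cccc2c1nnn2Cc1ccccc1` gives 80 nM in this assay.

Compound 2 and compound 1 share a core and differ by fluoro in place of hydrogen on an aromatic carbon; this gave a 1.4-fold lower number from compound 2 to compound 1 (0.15 log units; within the scatter). Compound 3 has another core; the difference between the two cores is not broken down here, and the values of compound 3 and compound 2 lie within the usual scatter of each other.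

Compound 4 `Fc1cccc(Cn2nnc3c(Br)cccc32)c1` has not yet been measured. It differs from compound 3 by fluoro in place of hydrogen on an aromatic carbon. This is the same kind of change as that from compound 2 to compound 1, but the surroundings differ: in compound 1 the fluoro sits ortho to a large group and meta to a chloro group, whereas in compound 4 it sits meta to a large group. Because a 1.4-fold lower number from compound 2 to compound 1 (0.15 log units; within the scatter) stayed within the scatter, compound 4 is expected to show a 1.2-fold lower number from compound 3 to compound 4 (0.09 log units; within the scatter) in this assay. The estimate for compound 4 in this assay is 65 nM, with a range from 30 nM to 140 nM.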

Compound 4, half-maximal effective concentration: 18 nM
Beside the measured number, compound 4's estimate is 3.6-fold (0.56 log units) above it, and the stated range ends above it.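

In this assay, fluoro in place of hydrogen on an aromatic carbon gave a 4.4-fold lower number from compound 3 to compound 4 (0.65 log units; beyond the scatter), so the change did not carry over at the same size from one core to the other: the same change on two cores in this assay, a 1.4-fold lower number (0.15 log units; within the scatter) from compound 2 to compound 1 and a 4.4-fold lower number (0.65 log units; beyond the scatter) from compound 3 to compound 4, 3.2-fold (0.50 log units) apart, beyond the scatter of two such steps. Among the compounds shown here, the number fell on both cores, but only the step on the core of compound 4 lies beyond the scatter. These two steps do not show why the size differs, since the cores and the surroundings of the fluoro both change, and they give no rule for any further core.

From the compounds shown here alone, it remains open whether another group in the same place, such as methoxy or an amine, would give a similar step. Going by these compounds, it is also open whether fluoro elsewhere on that ring would do so.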